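Fluoro in place of chloro at the limit of the assay

The source may report more compounds than this note shows. Statements on the series, on what has been measured and on what is new or still open speak of the compounds shown alone.

Measured so far in a functional assay on MOLT-4 cells (Homo sapiens) for antiproliferative activity, read by cell counting, with a stated time of 2 days; on this read-out lower numbers stand for stronger inhibition and higher numbers for weaker inhibition
- compound 1 `COc1ccc(Nc2nc(N)c(C(=O)c3ccc(OC)c(OC)c3)s2)cc1` gives 37 nM as a number
- compound 2 `COc1ccc(C(=O)c2sc(Nc3ccc(Cl)cc3)nc2N)cc1` gives > 10000 nM as a limit
- compound 3 `Nc1nc(Nc2ccc(Cl)cc2)sc1C(=O)c1ccccc1` gives > 10000 nM as a limit

Compound 2 reads > 10000 nM in this assay and this is a limit, not a number. Compound 3 stands at the same limit (> 10000 nM) and most of the values shown are of this kind (the limit of > 10000 nM in this assay, at which 2 of the 3 values shown sit). For the measured compounds named here, compound 1 is the only one with a readable value (37 nM).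

Compound 4 `COc1ccc(C(=O)c2sc(Nc3ccc(F)cc3)nc2N)cc1` keeps the core of compound 2 and carries fluoro in place of chloro on an aromatic carbon, para to a large group (fluoro in place of chloro on an aromatic carbon). Going by the values given here, the one measured step among the compounds at the limit is a step that the two limits leave unreadable from compound 2 to compound 3 and it gives no size to carry over. Among the compounds with values here, it is a change of methoxy to hydrogen, and no measured step exchanges one of these two halogens for the other. The expectation therefore rests on compound 2 alone, with > 10000 nM as its limit. No step beyond the scatter is expected in this assay and another limit is the most likely report. The estimated step is a step that the limit leaves unreadable from compound 2 to compound 4 on this reasoning. Compound 4 is expected at 12000 nM within a range of 3000 nM to 30000 nM on this estimate.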

Compound 4, half-maximal inhibitory concentration: > 10000 nM
Compound 4 was reported as a limit; the forecaster's own chance of this, stated with the estimate: 75%; the middle value is on the limit's open side.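

No new step can be read: compound 2 and compound 4 are both reported as limits, not numbers, so the step between them has no size, and both sit at the same limit: the limit of > 10000 nM in this assay, at which 3 of the 4 values shown sit.

The compounds shown leave open what size, if any, fluoro in place of chloro has on a compound with a readable value.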